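A few compounds are considered here, and "the series" means these few. Any claim that something is new, unique, unknown or untested is made for them only; others in the source may bear on it.

In an ADME assay on BJ cells (Homo sapiens) for cytotoxicity, read by fluorescence, with a stated time of 24 h (on this read-out lower numbers stand for stronger inhibition and higher numbers for weaker inhibition), compound 3 (`CCC1S/C(=N\N=C\c2c(-c3ccccc3)[nH]c3ccccc23)NC1=O`) gives > 50000 nM, which is a limit and not a number. Compound 1 (`O=C(CC1S/C(=N\N=C\c2c(-c3ccccc3)[nH]c3ccccc23)NC1=O)c1ccccc1`) gives > 50000 nM, also a limit, and this is the limit of > 50000 nM in this assay, at which 2 of the 3 values shown sit. Compound 2 (`CC(=O)OCCC1S/C(=N\N=C\c2c(-c3ccccc3)[nH]c3ccccc23)NC1=O`) gives a number, 37100 nM.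

Compound 4 (`O=C(CC1S/C(=N\N=C\c2c(-c3ccccc3)[nH]c3ccccc23)NC1=O)c1ccc(F)cc1`) differs from compound 3 by (4-fluorophenyl)carbonyl in place of methyl on a saturated chain carbon bound to a saturated ring carbon. Compound 1 carries benzoyl at that place, and the closest measured comparison is a step that the two limits leave unreadable from compound 1 to compound 3. The other two measured steps are an at least 1.3-fold lower number from compound 1 to compound 2 (0.12 log units; that floor lies within the scatter) and an at least 1.3-fold higher number from compound 2 to compound 3 (0.12 log units; that floor lies within the scatter), and neither is shown beyond the scatter. Given these steps, no change beyond the scatter is expected in this assay, so the estimated move is a number no higher from compound 3 to compound 4 (the limit leaves the size open). The expected value for compound 4 is 50000 nM, within an estimated range of 25000 nM to 100000 nM.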

Compound 4, half-maximal inhibitory concentration: > 50000 nM
Compound 4: no number, only a limit; the forecaster's own chance of this, stated with the estimate: 75%; the middle value sits exactly at the limit.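

In this assay compound 4 gives > 50000 nM, which is a limit and not a number. The one readable step is an at least 1.3-fold higher number from compound 2 to compound 4 (0.12 log units; that floor lies within the scatter), so (4-fluorophenyl)carbonyl at this place is not shown to differ from acetoxymethyl beyond the scatter, while the steps to compound 4 from compound 1 and compound 3 cannot be read. Fluoro on the aromatic carbon therefore adds no number, and most values now stand at one limit: the limit of > 50000 nM in this assay, at which 3 of the 4 values shown sit.

Going by these compounds, how far apart the compounds with limits lie stays open. Also open, on these data alone, is whether an amine or a carboxylic acid on the saturated chain carbon bound to a saturated ring carbon would give a clearly lower number.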